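Carboxy in place of methyl on the amide side chain

A few compounds are considered here, and "the series" means these few. Any claim that something is new, unique, unknown or untested is made for them only; others in the source may bear on it.

Measured so far in an assay for inhibition of NAD-dependent protein deacylase sirtuin-6 (Homo sapiens), read by HPLC, with stated times of 15 min and 1 h, tested at 333 uM; on this read-out lower numbers stand for less inhibition and higher numbers for more inhibition at the one concentration tested (going by the name of the read-out):
compound 1, `CCNC(=O)CCCSC[C@H](NC(=O)OCc1ccccc1)C(=O)Nc1ccccc1`: 15%
compound 2, `CCCCCCCCCCNC(=O)CCCSC[C@H](NC(=O)OCc1ccccc1)C(=O)Nc1ccccc1`: 28%
compound 3, `CCCCNC(=O)CCCSC[C@H](NC(=O)OCc1ccccc1)C(=O)Nc1ccccc1`: 26%
Not yet measured: compound 4, `O=C(O)CCCNC(=O)CCCSC[C@H](NC(=O)OCc1ccccc1)C(=O)Nc1ccccc1`.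

Compound 3 stands second highest of the three numbers. Against compound 2 the gap is a number 2 percentage points lower from compound 2 to compound 3 (within the scatter), so the two cannot be ordered; against compound 1 it is a number 11 percentage points higher from compound 1 to compound 3 (beyond the scatter).

The change to compound 4 is carboxy in place of methyl on a saturated chain carbon, three bonds along the chain from an amide-type nitrogen. Within the data shown here, no measured step introduces a carboxy group. Among the measured compounds shown here, the steps that bear on the same chain are those that lengthen it: a number 13 percentage points higher from compound 1 to compound 2 (beyond the scatter) and a number 11 percentage points higher from compound 1 to compound 3 (beyond the scatter), both modest, while a number 2 percentage points lower from compound 2 to compound 3 (within the scatter) shows that further lengthening beyond butyl adds nothing. Compound 4 keeps a chain of the same length as compound 3 and ends it in a carboxy group, for which the series gives no guide. The expectation is therefore no step beyond the scatter, with the uncertainty widened for the new group.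

Compound 4 is expected to give 22% in this assay, within 8% to 38%. The step this expectation implies is estimated as a number 4 percentage points lower from compound 3 to compound 4 (within the scatter).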

Compound 4, a percentage reported as inhibition, at one concentration (the size of the read-out at that concentration, not a potency): 35%
Compound 4: middle estimate off by 13 percentage points, on the low side; the range from low to high includes it.
By their numbers in this assay, from the lowest: compound 1; then compounds 3, 2 and 4 (each within the scatter of the next).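

In this assay, among these compounds, 3-carboxypropyl in place of butyl gives no step that can be read as a change: a number 9 percentage points higher from compound 3 to compound 4 (within the scatter), and a number 7 percentage points higher from compound 2 to compound 4 (within the scatter), so compound 4 cannot be ordered against compound 3 or compound 2. The remaining comparison, a number 20 percentage points higher from compound 1 to compound 4 (beyond the scatter), puts compound 4 with those two, so among these compounds the gain over compound 1 does not require an all-carbon chain end. Nothing in hand gives a reason for this result.

Open, from the compounds shown here alone, is whether a primary amine or a methyl ester at the same chain end would give a similar number, and whether a longer carboxylic acid chain would separate from compound 3 beyond the scatter. Going by these compounds, with one tested concentration, potency also remains open.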